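The source may report more compounds than this note shows. Statements on the series, on what has been measured and on what is new or still open speak of the compounds shown alone.

Measured so far:
- compound 1 `COc1cc(Cl)cc(-c2nn(-c3cccc(NC(=O)Nc4ccc(Cl)c(C(F)(F)F)c4)c3)cc2-c2ccncc2)c1` gives 64% in a functional assay on DU-145 cells (Homo sapiens) for inhibition, read by sulforhodamine B assay, with a stated time of 48 h, tested at 1 uM; on this read-out lower numbers stand for a stronger effect and higher numbers for a weaker effect at the one concentration tested
- compound 2 `COc1cc(Cl)cc(-c2nn(-c3cccc(NC(=O)Nc4cc(C(F)(F)F)cc(C(F)(F)F)c4)c3)cc2-c2ccncc2)c1` gives 27% in this assay
- compound 3 `COc1cc(Cl)cc(-c2nn(-c3cccc(NC(=O)Nc4ccc(Cl)c(Cl)c4)c3)cc2-c2ccncc2)c1` gives 93% in this assay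

Compound 3 has the highest number of the three, which here means the weakest effect: compound 1 lies lower, and compound 2 lies lower still, both beyond the scatter. Going by the values given here, the one step with a single change, a number 29 percentage points higher from compound 1 to compound 3 (beyond the scatter), shows that putting chloro in place of trifluoromethyl on the urea-side ring raised the number noticeably.

Compound 4 `COc1cc(Cl)cc(-c2nn(-c3cccc(NC(=O)Nc4cccc(C(F)(F)F)c4)c3)cc2-c2ccncc2)c1` has not yet been measured. It differs from compound 3 by 3-(trifluoromethyl)phenyl in place of 3,4-dichlorophenyl on an amide-type nitrogen. This change brings trifluoromethyl back onto that ring, the opposite direction of the step from compound 1 to compound 3, and also drops one chloro. The step from compound 1 to compound 3 therefore bears on it and suggests a lower number for compound 4, though the missing chloro means compound 1 is only a partial guide. Compound 4 is expected to land near compound 1, with an estimated step of a number 28 percentage points lower from compound 3 to compound 4 (beyond the scatter). The estimate for compound 4 is 65%, with a range from 40% to 90%.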

Compound 4, a percentage reported as activity, at one concentration (the size of the read-out at that concentration, not a potency): 73%
Compound 4: the middle estimate sits 8 percentage points below what was measured; the range from low to high includes it.
By their numbers in this assay, from the lowest: compound 2; then compounds 1 and 4 (each within the scatter of the next); then compound 3.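

Exchanging the whole aryl group on the amide-type nitrogen, 3-(trifluoromethyl)phenyl in place of 3,4-dichlorophenyl, gives a number 20 percentage points lower from compound 3 to compound 4 (beyond the scatter) in this assay, so the read-out responds to what this ring carries. Removing one trifluoromethyl, with hydrogen in its place, gives a number 46 percentage points higher from compound 2 to compound 4 (beyond the scatter), a large step showing that the second trifluoromethyl group counts for much in this small set. Removing the chloro, again with hydrogen in its place, gives a number 9 percentage points higher from compound 1 to compound 4 (within the scatter), so that chloro has no readable effect at the one concentration tested.

Nothing measured here explains why these changes act as they do. On these data alone, whether a nitrile or an amino group on this ring could stand in for the second trifluoromethyl stays open, as does whether these steps hold at other concentrations.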